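The source may report more compounds than this note shows. Statements on the series, on what has been measured and on what is new or still open speak of the compounds shown alone.

Measured compounds:
- compound 1, `CN(C)C(=S)N/N=C/c1cc2cccnc2s1`: 21400 nM
- compound 2, `CN(C)C(=S)N/N=C/c1ccc2cccnc2n1`: 630 nM
- compound 3, `N#Cc1ccc(NC(=S)N/N=C/c2ccc3ccccc3n2)cc1`: 23700 nM

Of the compounds shown here, three share a thiosemicarbazone backbone and have been tested in a functional assay on SGC-7901 cells (Homo sapiens) for antiproliferative activity, read by sulforhodamine B assay, with a stated time of 72 h; a lower number here means a stronger inhibitor, a higher number a weaker inhibitor. Compound 2 gives 630 nM in this assay, and compound 1 gives 21400 nM. Compound 3, which carries a 4-cyanophenyl on the amide-type nitrogen of the thiourea, gives 23700 nM: this is the highest of the three numbers, though it lies within the scatter of the number for compound 1, so the two cannot be told apart, while it stands well beyond the scatter from compound 2.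

The next compound, compound 4, `COc1cccc(NC(=S)N/N=C/c2ccc3ccccc3n2)c1`, differs from compound 3 in one place: 3-methoxyphenyl in place of 4-cyanophenyl on an amide-type nitrogen. For the measured compounds named here, no measured pair in this set shows what this exchange does, so the expectation rests on compound 3 alone. Going by the values given here, both groups that leave and enter are aryl rings of the same size with one hydrogen-bond acceptor each, and no measured step shows such an exchange moving the number in either direction. The step from compound 3 to compound 4 is therefore expected to be small, probably no larger than the scatter, as estimated at a 1.2-fold lower number from compound 3 to compound 4 (0.07 log units; within the scatter). Compound 4 is expected to give about 20000 nM in this assay, with a likely range from 7000 nM to 60000 nM.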

Compound 4, half-maximal inhibitory concentration: 79400 nM
Beside the measured number, compound 4's estimate is 4.0-fold (0.60 log units) below it; measured number above the stated range.
By their numbers in this assay, from the lowest: compound 2; then compounds 1 and 3 (each within the scatter of the next); then compound 4.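

In this assay, for the compounds shown here, the exchange of 4-cyanophenyl for 3-methoxyphenyl on the amide-type nitrogen gives a 3.4-fold higher number from compound 3 to compound 4 (0.53 log units; beyond the scatter) and is the first step in this set that can be read at a single place, showing that the number responds to which aryl group this nitrogen carries. The change is modest, yet it lies beyond the usual scatter, even though the two groups have the same count of heavy atoms, the same six-membered aromatic ring of carbon only, and the same counts of hydrogen-bond donors and acceptors, so these shared counts alone do not settle the number at this position. Nothing measured here accounts for the step, and no cause can be assigned to it.

The compounds shown leave open whether the higher number follows from losing the nitrile, from gaining the methoxy group, or from the different ring position, and a 4-methoxyphenyl or a 3-cyanophenyl on this nitrogen would separate these readings. They also leave open how either group compares with an unsubstituted phenyl or a simple methyl at the same place.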